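Cyano to pentafluoroethyl on the pyridinone analogue

This account rests on a few compounds, and the source may have more. Where it says the series, first, only, none or still open, it means among the compounds named here.

Measured compounds in a functional assay (aorta) with Rattus norvegicus as the target; a lower number here means that less compound is needed, a higher number that more compound is needed for the effect:
compound 1 `N#Cc1ccc2c(c1)[C@@H](N1CCCC1=O)[C@H](O)C(CF)(CF)O2` gives 85.1 nM
compound 2 `O=C1CCCN1[C@@H]1c2cc(C(F)(F)C(F)(F)F)ccc2OC(CF)(CF)[C@H]1O` gives 6.31 nM
compound 3 `N#Cc1ccc2c(c1)[C@@H](n1ccccc1=O)[C@H](O)C(CF)(CF)O2` gives 148 nM

Compound 3 stands highest of the three numbers. Its nearest neighbour is compound 1, whose step to compound 3 is a 1.7-fold higher number from compound 1 to compound 3 (0.24 log units; within the scatter) and thus not separable from noise; its furthest is compound 2, which sits well beyond the scatter below it.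

Compound 4 `O=c1ccccn1[C@@H]1c2cc(C(F)(F)C(F)(F)F)ccc2OC(CF)(CF)[C@H]1O` is the unmeasured partner of compound 3, differing from it as follows: 1,1,2,2,2-pentafluoroethyl in place of cyano on an aromatic carbon. The cyano leaves and the 1,1,2,2,2-pentafluoroethyl enters on an aromatic carbon of the six-membered carbon-only ring of the fused system.

Among the measured compounds shown here, one measured step bears directly on this change. The same replacement of cyano by 1,1,2,2,2-pentafluoroethyl, on the shared core bearing the five-membered ring, gave a 13-fold lower number from compound 1 to compound 2 (1.13 log units; beyond the scatter). Since compound 1 and compound 3 lie within the scatter of each other, the pair of compound 3 and compound 4 is expected to behave in the same way, so a large downward step in this assay is expected, with a 12-fold lower number from compound 3 to compound 4 (1.09 log units; beyond the scatter) as the anticipated size.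

Compound 4 is therefore estimated at 12 nM, with a likely range from 5 nM to 30 nM.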

Compound 4, half-maximal effective concentration: 12 nM
Compound 4: the middle estimate sits on the measured number at the digits printed; the measured number falls inside the stated range.
By their numbers in this assay, from the lowest: compounds 2 and 4 (each within the scatter of the next); then compounds 1 and 3 (each within the scatter of the next).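

The new result gives a 12-fold lower number from compound 3 to compound 4 (1.09 log units; beyond the scatter) in this assay, so the large drop on replacing cyano with 1,1,2,2,2-pentafluoroethyl on this aromatic carbon is not confined to the core bearing the five-membered ring. The size of the step carries over from one core to the other: the same change on two cores in this assay, a 13-fold lower number (1.13 log units; beyond the scatter) from compound 1 to compound 2 and a 12-fold lower number (1.09 log units; beyond the scatter) from compound 3 to compound 4, 1.1-fold (0.04 log units) apart, within the scatter of two such steps. Among the compounds shown here, the exchange of groups on the saturated ring carbon, previously seen only with cyano on the aromatic ring, also stays within the scatter with 1,1,2,2,2-pentafluoroethyl, at a 1.9-fold higher number from compound 2 to compound 4 (0.28 log units; within the scatter), and the two readings agree: the same change on two cores in this assay, a 1.7-fold higher number (0.24 log units; within the scatter) from compound 1 to compound 3 and a 1.9-fold higher number (0.28 log units; within the scatter) from compound 2 to compound 4, 1.1-fold (0.04 log units) apart, within the scatter of two such steps.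

The compounds shown compare only two groups on this aromatic carbon, so they leave open how a trifluoromethyl group, a longer perfluorinated chain or an amine would read there. For the compounds shown here, they also cover only two groups on the saturated ring carbon and a single assay, so whether the step keeps its size with other groups at that site, or holds in any other test, remains unknown.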